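Hydroxy in Place of Hydrogen: a Second Placement

A few compounds are considered here, and "the series" means these few. Any claim that something is new, unique, unknown or untested is made for them only; others in the source may bear on it.

Compound 1 `CC(C)c1noc(N2CCC(Oc3cc(N4CCc5cc(N6CCCCC6=O)ccc54)ncn3)CC2)n1` gives 3.8 in a physicochemical assay for lipophilicity, measured as octanol-water partition, at pH 7.4 (on this read-out higher numbers stand for higher lipophilicity and lower numbers for lower lipophilicity), the highest of the three numbers measured. Compound 2 `CC(C)c1noc(N2CCC(Oc3cc(N4CCc5cc(N6CC(O)CCC6=O)ccc54)ncn3)CC2)n1` gives 2.6 and compound 3 `CC(C)c1noc(N2CCC(Oc3cc(N4CCc5cc(S(=O)(=O)CCO)ccc54)ncn3)CC2)n1` gives 2.7, both well below compound 1. The change that leads to compound 4 `CC(C)c1noc(N2CCC(Oc3cc(N4CCc5cc(N6CCC(O)CC6=O)ccc54)ncn3)CC2)n1` is hydroxy in place of hydrogen on a saturated ring carbon. Within the data shown here, the closest precedent is a number 1.20 log units lower from compound 1 to compound 2 (beyond the scatter), the same kind of change on the same ring; the step of a number 1.10 log units lower from compound 1 to compound 3 (beyond the scatter) was of like size. Compound 4 is therefore expected to drop by a comparably large amount, a number 1.10 log units lower from compound 1 to compound 4 (beyond the scatter). Compound 4 is estimated at 2.7, within a range from 2.2 to 3.2.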

Compound 4, distribution coefficient: 2.8
Compound 4: middle estimate off by 0.10 log units, on the low side; the range from low to high includes it.
By their numbers in this assay, from the lowest: compounds 2, 3 and 4 (each within the scatter of the next); then compound 1.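

Hydroxy at this second placement, three ring bonds from the ring nitrogen, still brings a number 1.00 log units lower from compound 1 to compound 4 (beyond the scatter) in this assay, so among these compounds the step does not depend on one ring carbon. The two hydroxy placements cannot be told apart, with a number 0.20 log units higher from compound 2 to compound 4 (within the scatter), and a number 0.10 log units higher from compound 3 to compound 4 (within the scatter) leaves the (2-hydroxyethyl)sulfonyl group level with them as well. Nothing available bears on what lies behind these steps. As far as these compounds go, whether an amine or a carboxylic acid on this same ring carbon would give a step of like size remains open.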